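The source may report more compounds than this note shows. Statements on the series, on what has been measured and on what is new or still open speak of the compounds shown alone.

Measured so far, in an ADME assay on MT4 cells (Homo sapiens) for cytotoxicity, read by MTT assay; a higher number here means that more compound is tolerated, a lower number that less compound is tolerated:

Compound 1, `CCCCCOc1ccc(C(=O)N(C(=S)OCCN2C(=O)c3ccccc3C2=O)c2ccc(F)cc2)cc1`, gives > 100000 nM, which is a limit of this assay rather than a number.
Compound 2, `Cc1ccccc1C(=O)N(C(=S)OCCN1C(=O)c2ccccc2C1=O)c1ccc(Cl)cc1`, gives 21000 nM.
Compound 3, `O=C1c2ccccc2C(=O)N1CCOC(=S)N(C(=O)c1ccc(Br)cc1)c1ccc(Br)cc1`, gives 73000 nM.

Among the two numbers available, compound 2 stands lowest. Its nearest neighbour is compound 3, whose higher number lies beyond the usual scatter of this assay, so compound 2 is the less well tolerated of the pair. Compound 1 sits at the limit of > 100000 nM in this assay, at which 1 of the 3 values shown sits, and that is all that can be said of it.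

The piece now turns to compound 4, `O=C1c2ccccc2C(=O)N1CCOC(=S)N(C(=O)c1cc(F)cc(F)c1)c1ccc(Cl)cc1`, which has not yet been measured in this assay. Set against compound 2, the change is 3,5-difluorophenyl in place of 2-methylphenyl on a carbonyl carbon. Among the compounds with values here, no step between measured compounds shows what a change of this kind does here, so the expectation rests on the spread of the numbers seen so far, which stay within a modest band. The step from compound 2 to compound 4 is expected to be a 1.7-fold higher number from compound 2 to compound 4 (0.22 log units; within the scatter), a move toward a higher number but small enough that it may not pass the scatter. Compound 4 is therefore expected to give about 35000 nM, with a range from 12000 nM to 100000 nM.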

Compound 4, half-maximal cytotoxic concentration: 59000 nM
For compound 4 the middle estimate is 1.7-fold (0.23 log units) below the measured one, within the range that was stated.
By their numbers in this assay, from the lowest: compound 2; then compounds 4 and 3 (each within the scatter of the next). At a limit, above all of these: compound 1.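

In this assay, within the data shown here, 3,5-difluorophenyl in place of 2-methylphenyl on a carbonyl carbon gives a 2.8-fold higher number from compound 2 to compound 4 (0.45 log units; beyond the scatter), the first step in this set between compounds that differ in one place. The earlier compounds shown here differed from one another in more than one place, and their spread could not be tied to any single site; this step shows that a change at this position alone can carry the number beyond the scatter, toward more compound tolerated, though the step remains modest. The compounds shown offer no measured reason for this step.

Still open, as far as these compounds go, is whether the step comes from losing the methyl of 2-methylphenyl, from gaining the fluorine atoms of 3,5-difluorophenyl, or from both, a question that an unsubstituted phenyl on the same carbonyl carbon would help to settle. Also open, from the compounds shown here alone, is how an amine, a carboxylic acid or a longer chain on that carbonyl carbon would move the number, and whether the same exchange gives a similar step when the rest of the molecule differs.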